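The source may hold more compounds than are shown below. What is called first, only, known or untested is meant among the compounds shown, and "the series" means these compounds.

In an ADME assay on MT4 cells (Homo sapiens) for cytotoxicity, read by MTT assay, with a stated time of 4 days (on this read-out higher numbers stand for lower toxicity in this test and lower numbers for higher toxicity in this test), compound 2 `N#Cc1ccc(Nc2nc(Oc3ccc(Cl)cc3Cl)c3ccccc3n2)cc1` gives 32000 nM, the second highest of the three numbers. Compound 3 `Cc1cc(Br)c(Oc2nc(Nc3ccc(C#N)cc3)nc3ccccc23)c(Br)c1` gives 25000 nM in this assay, and the step of a 1.3-fold lower number from compound 2 to compound 3 (0.11 log units; within the scatter). Compound 1 `COc1cc(C#N)cc(OC)c1Oc1nc(Nc2ccc(C#N)cc2)nc2ccccc12` gives 194000 nM in this assay, the furthest from compound 2 and beyond the scatter.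

Compound 4 `Cc1cccc(Oc2nc(Nc3ccc(C#N)cc3)nc3ccccc23)c1` differs from compound 2 in one place: 3-methylphenyl in place of 2,4-dichlorophenyl on an oxygen on an aromatic ring. Going by the values given here, the only measured step that bears on this, the swap of one phenyl for another on the same oxygen from compound 2 to compound 3, stayed within the scatter. Compound 4 is therefore expected to show no step beyond the scatter, with a 1.4-fold higher number from compound 2 to compound 4 (0.15 log units; within the scatter) in this assay. The value of compound 4 is estimated at 45000 nM, between 15000 nM and 150000 nM.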

Compound 4, half-maximal cytotoxic concentration: 355000 nM
Beside the measured number, compound 4's estimate is 7.9-fold (0.90 log units) below it, outside the stated range (above it).
By their numbers in this assay, from the lowest: compounds 3 and 2 (each within the scatter of the next); then compounds 1 and 4 (each within the scatter of the next).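

On this oxygen on an aromatic ring, the choice of phenyl group can move the number far, although the earlier swap there stayed within the scatter. In this assay the result is an 11-fold higher number from compound 2 to compound 4 (1.05 log units; beyond the scatter) and, against the dibromo group, a 14-fold higher number from compound 3 to compound 4 (1.15 log units; beyond the scatter), both towards lower toxicity in this test. Going by these compounds alone, nothing measured here explains why this change moves the number so far. The compounds shown leave open whether these steps go with the methyl group that enters or with the halogens that leave. As far as these compounds go, how a phenyl carrying an amine or a carboxylic acid would read also stays open.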